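Replacing ethoxycarbonyl with hydroxymethyl on the shared core

This account rests on a few compounds, and the source may have more. Where it says the series, first, only, none or still open, it means among the compounds named here.

Measured so far in a functional assay (trachea) with Cavia porcellus as the target; a higher number here means a weaker inhibitor, a lower number a stronger inhibitor
- compound 1 `CC(C)=CCn1nc(-c2cccnc2)c2ccccc2c1=O` gives 1380 nM
- compound 2 `CCOC(=O)Cn1nc(-c2cccnc2)c2ccccc2c1=O` gives 43700 nM

Compound 2 has the higher of these two numbers, which makes it the weaker inhibitor. Compound 3 `O=c1c2ccccc2c(-c2cccnc2)nn1CCO` differs from compound 2 by hydroxymethyl in place of ethoxycarbonyl on a saturated chain carbon bound to an aromatic nitrogen in one place: hydroxymethyl in place of ethoxycarbonyl on a saturated chain carbon bound to an aromatic nitrogen. For the measured compounds named here, only one measured step bears on this place, the large 32-fold higher number from compound 1 to compound 2 (1.50 log units; beyond the scatter) with ethoxycarbonyl coming in, and it says nothing direct about hydroxymethyl. A moderate step toward a lower number is therefore expected in this assay for compound 3, though one within the scatter remains possible. The estimated change is a 2.9-fold lower number from compound 2 to compound 3 (0.46 log units; beyond the scatter) by this reasoning. For compound 3 the estimated value is 15000 nM with an expected range from 3000 nM to 70000 nM as the likely span.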

Compound 3, half-maximal inhibitory concentration: 4570 nM
Beside the measured number, compound 3's estimate is 3.3-fold (0.52 log units) above it, within the range that was stated.
By their numbers in this assay, from the lowest: compound 1; then compound 3; then compound 2.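

Replacing ethoxycarbonyl with hydroxymethyl on this saturated chain carbon gives a 9.6-fold lower number from compound 2 to compound 3 (0.98 log units; beyond the scatter) in this assay, so a chain carrying oxygen need not be as weak as compound 2. Hydroxymethyl still falls short of 2-methylprop-1-en-1-yl, with a 3.3-fold higher number from compound 1 to compound 3 (0.52 log units; beyond the scatter), leaving compound 1 the strongest inhibitor of the three. No measured evidence shows why these groups differ. Still open, going by these compounds, is how an amine or a carboxylic acid would fare at this place, and whether a longer chain ending in hydroxyl would give a lower number than compound 3.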